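The source may hold more compounds than are shown below. What is called first, only, known or untested is meant among the compounds shown, and "the series" means these compounds.

Measured compounds:
- compound 1 `C=CC(=O)Nc1cccc(Oc2nc(Nc3cccc(C#N)c3)nc3c2CSCC3)c1` gives 34900 nM in a functional assay on HeLa cells (Homo sapiens) for antiproliferative activity, read by MTT assay, with a stated time of 72 h; on this read-out lower numbers stand for stronger inhibition and higher numbers for weaker inhibition
- compound 2 `C/C=C/C(=O)Nc1cccc(Oc2nc(Nc3cccc(C#N)c3)nc3c2CSCC3)c1` gives 12800 nM in this assay
- compound 3 `C=CC(=O)Nc1cccc(Oc2nc(Nc3ccc(OC)nc3)nc3c2CSCC3)c1` gives 26300 nM in this assay

Three compounds share a core and differ at two places: the group on the carbonyl carbon of the amide and the aryl group on the nitrogen on an aromatic ring. Compound 1 and compound 2 differ by prop-1-en-1-yl in place of vinyl on a carbonyl carbon, and this change gave a 2.7-fold lower number from compound 1 to compound 2 (0.44 log units; beyond the scatter). Compound 1 and compound 3 differ by 6-methoxypyridin-3-yl in place of 3-cyanophenyl on a nitrogen on an aromatic ring; here the step was a 1.3-fold lower number from compound 1 to compound 3 (0.12 log units; within the scatter), so compound 1 and compound 3 cannot be told apart on this read-out. The two cores thus differ only in the aryl group on the nitrogen on an aromatic ring, and that difference did not shift the number in a way that stands out of the scatter.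

Compound 4 `C/C=C/C(=O)Nc1cccc(Oc2nc(Nc3ccc(OC)nc3)nc3c2CSCC3)c1` has not yet been measured. It differs from compound 3 by prop-1-en-1-yl in place of vinyl on a carbonyl carbon, which is the same change as that from compound 1 to compound 2: the place lines agree word for word, the carbonyl carbon whose other neighbour is an amide-type nitrogen. Going by the values given here, with only one earlier instance of the change, the expectation rests on that single step. Since compound 3 stands close to compound 1, as a 1.3-fold lower number from compound 1 to compound 3 (0.12 log units; within the scatter) shows, the same change is expected to move compound 3 by roughly the amount seen in a 2.7-fold lower number from compound 1 to compound 2 (0.44 log units; beyond the scatter), giving an expected step of a 2.5-fold lower number from compound 3 to compound 4 (0.40 log units; beyond the scatter). Compound 4 is therefore estimated at 10500 nM, with a range of 4000 nM to 28000 nM allowing for the scatter of a single prior example.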

Compound 4, half-maximal inhibitory concentration: 16500 nM
Compound 4: the middle estimate sits 1.6-fold (0.20 log units) below what was measured; low and high end bracket the measured number.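

In this assay, prop-1-en-1-yl in place of vinyl on a carbonyl carbon gives a 1.6-fold lower number from compound 3 to compound 4 (0.20 log units; within the scatter), and this step does not differ beyond the scatter from the step seen earlier on the other core: the same change on two cores in this assay, a 2.7-fold lower number (0.44 log units; beyond the scatter) from compound 1 to compound 2 and a 1.6-fold lower number (0.20 log units; within the scatter) from compound 3 to compound 4, 1.7-fold (0.23 log units) apart, within the scatter of two such steps

The aryl change on a nitrogen on an aromatic ring, 6-methoxypyridin-3-yl in place of 3-cyanophenyl, gives a 1.3-fold higher number from compound 2 to compound 4 (0.11 log units; within the scatter), and it likewise reads the same with either group on the carbonyl carbon: the same change on two cores in this assay, a 1.3-fold lower number (0.12 log units; within the scatter) from compound 1 to compound 3 and a 1.3-fold higher number (0.11 log units; within the scatter) from compound 2 to compound 4, 1.7-fold (0.23 log units) apart, within the scatter of two such steps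

The two changes therefore look additive across these four compounds, but this rests on a single pair of cores, and since the step on the second core lies within the scatter, it does not show on its own that prop-1-en-1-yl lowers the number there; agreement between the steps is not proof of a shared size.

Still open, going by these compounds, is whether an ethyl group without the double bond, a longer chain or a chain bearing an amine on the carbonyl carbon would follow the same step. Equally open, on these data alone, is whether the steps would stay the same with a different aryl group on the nitrogen, such as a phenyl carrying a carboxylic acid.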